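A few compounds are considered here, and "the series" means these few. Any claim that something is new, unique, unknown or untested is made for them only; others in the source may bear on it.

Measured in a functional assay on KETR3 cells (Homo sapiens) for inhibition, read by MTT assay, with a stated time of 120 h; a lower number here means a stronger inhibitor, a higher number a weaker inhibitor:
compound 1 `CC(NC(=O)/C=C/c1ccc(NC(=O)Nc2ccc(Cl)c(C(F)(F)F)c2)cc1)c1ccccc1` gives 21200 nM
compound 2 `CC(NC(=O)c1ccc(-c2ccc(NC(=O)Nc3cc(C(F)(F)F)ccc3Cl)cc2)cc1)c1ccccc1` gives 16800 nM
compound 3 `CC(NC(=O)/C=C/c1ccc(NC(=O)Nc2cc(C(F)(F)F)ccc2Cl)cc1)c1ccccc1` gives 14300 nM

Among the measured compounds shown here, all three numbers lie within the usual scatter of one another, so none of the measured compounds is set apart from the others in this assay. Compound 3 and compound 1 share one core and differ by 4-chloro-3-(trifluoromethyl)phenyl in place of 2-chloro-5-(trifluoromethyl)phenyl on an amide-type nitrogen; that change gave a 1.5-fold higher number from compound 3 to compound 1 (0.17 log units; within the scatter). Compound 2 is built on a different core, and the difference between the core of compound 2 and the core of compound 3 is not broken down here; the two values show only that they fall within the scatter of each other.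

Compound 4 `CC(NC(=O)c1ccc(-c2ccc(NC(=O)Nc3ccc(Cl)c(C(F)(F)F)c3)cc2)cc1)c1ccccc1` has not yet been measured. It stands to compound 2 as compound 1 stands to compound 3: 4-chloro-3-(trifluoromethyl)phenyl in place of 2-chloro-5-(trifluoromethyl)phenyl on an amide-type nitrogen. The place of the change is the same in both pairs, so this is the same change carried onto the second core. Since the first instance gave a 1.5-fold higher number from compound 3 to compound 1 (0.17 log units; within the scatter), compound 4 is expected to show a 1.3-fold higher number from compound 2 to compound 4 (0.12 log units; within the scatter). The estimated value for compound 4 in this assay is 22000 nM, expected to fall between 11000 nM and 45000 nM.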

Compound 4, half-maximal inhibitory concentration: 19300 nM
Beside the measured number, compound 4's estimate is 1.1-fold (0.06 log units) above it; measured number inside the range.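

In this assay, 4-chloro-3-(trifluoromethyl)phenyl in place of 2-chloro-5-(trifluoromethyl)phenyl on the amide-type nitrogen gave a 1.1-fold higher number from compound 2 to compound 4 (0.06 log units; within the scatter). Set beside the earlier instance, the change shows no detectable difference in size between the two cores: the same change on two cores in this assay, a 1.5-fold higher number (0.17 log units; within the scatter) from compound 3 to compound 1 and a 1.1-fold higher number (0.06 log units; within the scatter) from compound 2 to compound 4, 1.3-fold (0.11 log units) apart, within the scatter of two such steps. Among the compounds shown here, this shows only that the exchange of these two substituted phenyl groups stays within the scatter on both cores; it does not establish a real effect of the change or a real direction for it, and two cores give no basis for predicting its size on a third.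

Still open, going by these compounds, is whether any group other than these two arrangements of chlorine and trifluoromethyl would separate compounds, for example a nitrile or a carboxylic acid in place of the trifluoromethyl, or an amine in place of the chlorine. Also open is whether a step beyond the scatter can be obtained on either core, since the compounds shown give none.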